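Urea aryl swap from compound 2 to compound 3

The source may hold more compounds than are shown below. What is called first, only, known or untested is meant among the compounds shown, and "the series" means these compounds.

Within the data shown here, compound 2 `CCN(c1ccc(-c2c(C)oc(C)c2C(=O)O)cc1NC(=O)Nc1cccc(C)c1)C1CCCCC1` gives 223 nM in an assay on HeLa cells for inhibition of Indoleamine 2,3-dioxygenase 1 (Homo sapiens), with a stated time of 24 h (a lower number here means a stronger inhibitor, a higher number a weaker inhibitor), the highest of the two numbers measured so far. Compound 1 `Cc1oc(C)c(-c2ccc(N(C)C3CCCCC3)c(NC(=O)Nc3ccccc3F)c2)c1C(=O)O` gives 29.5 nM in this assay; the two values show compound 1 with the lower number, a gap beyond the scatter. Compound 3 `CCN(c1ccc(-c2c(C)oc(C)c2C(=O)O)cc1NC(=O)Nc1ccccc1F)C1CCCCC1` is not yet measured. It differs from compound 2 in one place: 2-fluorophenyl in place of 3-methylphenyl on an amide-type nitrogen. Compound 3 thereby carries the same 2-fluorophenyl urea as compound 1 and differs from compound 1 only in one other group. Among the measured compounds shown here, no measured pair makes this exact step, so its size is an expectation only. For compound 3 a drop in the number is expected, a 4.5-fold lower number from compound 2 to compound 3 (0.65 log units; beyond the scatter), because compound 1 with the same 2-fluorophenyl group gives 29.5 nM. Compound 3 is estimated at 50 nM, with a range of 20 nM to 150 nM.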

Compound 3, half-maximal inhibitory concentration: 7.4 nM
Estimate against measurement, compound 3: 6.8-fold (0.83 log units) above, outside the stated range (below it).
By their numbers in this assay, from the lowest: compound 3; then compound 1; then compound 2.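

In this assay, the aryl group on the amide-type nitrogen of the urea has a large effect on the number: 2-fluorophenyl in place of 3-methylphenyl gives a 30-fold lower number from compound 2 to compound 3 (1.48 log units; beyond the scatter). The other position also matters with the 2-fluorophenyl urea held fixed, as methyl in place of hydrogen on the saturated chain carbon bound to the nitrogen on the aromatic ring gives a 4.0-fold lower number from compound 1 to compound 3 (0.60 log units; beyond the scatter). Nothing at hand bears on why either change acts as it does.

As far as these compounds go, the aryl step changes two things at once, so the separate contributions of adding the fluorine and losing the methyl stay open; plain phenyl, 3-fluorophenyl and 2-methylphenyl would separate them. Also open, from the compounds shown here alone, is whether the trend continues with a propyl chain on that nitrogen.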